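The source may report more compounds than this note shows. Statements on the series, on what has been measured and on what is new or still open speak of the compounds shown alone.

Compound 1 `Cc1cn([C@@H]2O[C@H](CO[Si](C)(C)C(C)(C)C(C)C)[C@@]3(OS(=O)(=O)C=C3NC(=O)NC(=O)c3ccccc3)[C@H]2O[Si](C)(C)C(C)(C)C)c(=O)n(C)c1=O` — > 50000 nM
Compound 2 `Cc1cn([C@@H]2O[C@H](CO[Si](C(C)C)(C(C)C)C(C)C)[C@@]3(OS(=O)(=O)C=C3NC(=O)NC(=O)c3ccccc3)[C@H]2O[Si](C)(C)C(C)(C)C)c(=O)n(C)c1=O` — > 100000 nM

In an ADME assay on HEL cells (Homo sapiens) for cytotoxicity, with a stated time of 3 days (a lower number here means that less compound is tolerated, a higher number that more compound is tolerated), compound 1 gives > 50000 nM; this is a limit of the assay, not a number. Compound 2 gives > 100000 nM in this assay, again only a limit. Compound 1 thus stands at the limit of > 50000 nM in this assay, at which 1 of the 2 values shown sits, and nothing finer is known of it. The step that the two limits leave unreadable from compound 1 to compound 2 is left unreadable by the two limits.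

Compound 3 `Cc1cn([C@@H]2O[C@H](CO[Si](C)(C)C(C)(C)C(C)C)[C@@]3(OS(=O)(=O)C=C3NC(=O)NC(=O)c3ccccc3)[C@H]2O[Si](C)(C)C(C)(C)C(C)C)c(=O)n(C)c1=O` differs from compound 1 by isopropyl in place of methyl on a saturated chain carbon bound to two saturated chain carbons and a silicon atom. For the measured compounds named here, only the step from compound 1 to compound 2 bears on a change of this kind, and its size cannot be read, so no step beyond the scatter is expected in this assay. Compound 3 is therefore estimated at 100000 nM, within 50000 nM to 200000 nM. The expected step is a step that the limit leaves unreadable from compound 1 to compound 3, most likely again reported only as a limit.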

Compound 3, half-maximal cytotoxic concentration: > 50000 nM
Compound 3: no number, only a limit; the forecaster's own chance of this, stated with the estimate: 85%; the middle value does not contradict the limit.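

Compound 1 and compound 3 are both reported only as limits of the assay, and the step between them cannot be read. The compounds shown leave open at what concentration any of them would become cytotoxic in this assay.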